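From 1,3-thiazol-5-yl to cyclohexyl on the shared core

The source may hold more compounds than are shown below. What is called first, only, known or untested is meant among the compounds shown, and "the series" means these compounds.

Values so far in an ADME assay on Huh-7 cells (Homo sapiens) for cytotoxicity, with a stated time of 72 h (on this read-out lower numbers stand for higher toxicity in this test and higher numbers for lower toxicity in this test), are all limits:
- compound 1 `COCN(c1ccc2c(c1)S(=O)(=O)N=C(c1c(O)c(-c3cccs3)nn(CCC(C)C)c1=O)N2)S(C)(=O)=O` gives > 1000 nM (a limit)
- compound 2 `CC(C)CCn1nc(-c2cccs2)c(O)c(C2=NS(=O)(=O)c3cc(CS(C)(=O)=O)ccc3N2)c1=O` gives > 33000 nM (a limit)
- compound 3 `CC(C)CCn1nc(-c2cncs2)c(O)c(C2=NS(=O)(=O)c3cc(NS(C)(=O)=O)ccc3N2)c1=O` gives > 33000 nM (a limit)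

Compound 3 stands at the limit of > 33000 nM in this assay, at which 2 of the 3 values shown sit, and so offers a limit rather than a number. In compound 4 `CC(C)CCn1nc(C2CCCCC2)c(O)c(C2=NS(=O)(=O)c3cc(NS(C)(=O)=O)ccc3N2)c1=O` cyclohexyl stands in place of 1,3-thiazol-5-yl on an aromatic carbon (cyclohexyl in place of 1,3-thiazol-5-yl on an aromatic carbon) and the rest of the structure is unchanged. Within the data shown here, no measured step covers this exchange. Among the measured compounds shown here, the one step measured between two compounds differing in a single place is a step that the two limits leave unreadable from compound 1 to compound 2 and concerns another group, so it offers no size to carry over. The expectation therefore rests on compound 3 alone, whose limit of > 33000 nM is the only anchor. No step beyond the scatter is expected in this assay and no direction can be assigned, though this is a weakly supported expectation. The estimated change is a number no higher from compound 3 to compound 4 (the limit leaves the size open) and should be read with that caution. Compound 4 is expected to give 33000 nM with an estimated range of 12000 nM to 60000 nM.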

Compound 4, half-maximal cytotoxic concentration: > 1000 nM
Compound 4 ended at the assay's limit; the forecaster's own chance of this, stated with the estimate: 80%; the middle value is on the limit's open side.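

In this assay compound 3 gives > 33000 nM, which is a limit. Compound 4 gives > 1000 nM, which is also a limit. No step can be read between compound 3 and compound 4. The compounds shown leave open whether cyclohexyl in place of 1,3-thiazol-5-yl changes the result in this assay at all, and in which direction.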